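Isobutyl to propyl on a shared core

The source may hold more compounds than are shown below. What is called first, only, known or untested is meant among the compounds shown, and "the series" means these compounds.

Compounds measured in a physicochemical assay for acid dissociation
- compound 1 `C#CCOc1noc2c1CNCC2` gives 7.6
- compound 2 `CC(C)Oc1noc2c1CNCC2` gives 7.5
- compound 3 `CC(C)COc1noc2c1CNCC2` gives 7.7

In this assay compound 3 stands at 7.7 and is not separated from the other two. The steps reaching it read a number 0.10 log units higher from compound 1 to compound 3 (within the scatter) and a number 0.20 log units higher from compound 2 to compound 3 (within the scatter) and leave all three compounds together.

Compound 4 `CCCOc1noc2c1CNCC2` comes next. It differs from compound 3 by hydrogen in place of methyl on a saturated chain carbon bound to two saturated chain carbons in one change, hydrogen in place of methyl on a saturated chain carbon bound to two saturated chain carbons, which turns isobutyl into propyl.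

Within the data shown here, no measured step is this same change. The closest evidence comes from other exchanges of the group on the oxygen, namely a number 0.10 log units lower from compound 1 to compound 2 (within the scatter) for isopropyl in place of propargyl and a number 0.20 log units higher from compound 2 to compound 3 (within the scatter) for isobutyl in place of isopropyl. With these as a guide, no step beyond the scatter is expected. The estimated step is a number 0.10 log units lower from compound 3 to compound 4 (within the scatter) and nothing larger is expected. For compound 4 the expected value is 7.6 with an estimated range from 7.3 to 7.9 as the likely span.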

Compound 4, acid dissociation constant: 7.6
Compound 4: middle estimate and measured number agree at the digits printed, within the range that was stated.
By their numbers in this assay, from the lowest: compounds 2, 1, 4 and 3 (each within the scatter of the next).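

In this assay the exchange of methyl for hydrogen on a saturated chain carbon bound to two saturated chain carbons now has a reading of its own, which is a number 0.10 log units lower from compound 3 to compound 4 (within the scatter) and leaves isobutyl and propyl unseparated. The unbranched propyl chain also stays with isopropyl, at a number 0.10 log units higher from compound 2 to compound 4 (within the scatter) and with propargyl, at no change at the digits printed from compound 1 to compound 4 (within the scatter) so this small series adds a straight chain without separating any of the compounds. Across these four compounds, then, no exchange of the group on the oxygen gives a step beyond the scatter.

From the compounds shown here alone, whether a much longer chain, an amine or a carboxylic acid on that oxygen would give such a step remains open. Nothing measured here accounts for the closeness of these numbers.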